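A few compounds are considered here, and "the series" means these few. Any claim that something is new, unique, unknown or untested is made for them only; others in the source may bear on it.

Working notes on the series.

In a functional assay on SN12C cells (Homo sapiens) for inhibition, read by sulforhodamine B assay, with a stated time of 48 h (on this read-out lower numbers stand for higher toxicity in this test and higher numbers for lower toxicity in this test), compound 1 `COc1cc(-c2nn(-c3cccc(NC(=O)Nc4cc(C(F)(F)F)cc(C(F)(F)F)c4)c3)cc2-c2ccncc2)ccc1Cl` returns only a limit of the test, > 50000 nM. Compound 2 `COc1cc(-c2nn(-c3cccc(NC(=O)Nc4ccc(Cl)c(Cl)c4)c3)cc2-c2ccncc2)ccc1Cl` likewise returns a limit, > 50000 nM. Compound 3 `O=C(Nc1cccc(-n2cc(-c3ccncc3)c(-c3ccc(Cl)c(O)c3)n2)c1)Nc1ccc(Cl)c(Cl)c1` returns a limit as well, > 32500 nM. The single step shown, a step that the two limits leave unreadable from compound 2 to compound 3, puts hydrogen in place of methyl on an oxygen on an aromatic ring and cannot be read between the two limits. Compound 2 therefore stands only at a limit: the limit of > 50000 nM in this assay, at which 2 of the 3 values shown sit, shared with compound 1, while compound 3 sits at the limit of > 32500 nM in this assay, at which 1 of the 3 values shown sits. Among the compounds with values here, no measured compound gives a number.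

Compound 4 `COc1cc(-c2nn(-c3cccc(NC(=O)c4ccccc4)c3)cc2-c2ccncc2)ccc1Cl` differs from compound 2 by phenyl in place of (3,4-dichlorophenyl)amino on a carbonyl carbon. Within the data shown here, no measured step touches this carbonyl side, and the one step that exists is unreadable, so no direction can be drawn from the series. The expected step of a number no higher from compound 2 to compound 4 (the limit leaves the size open) is estimated as none beyond the scatter. Compound 4 is expected at 50000 nM, within 20000 nM to 120000 nM, most probably reported again only as a limit.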

Compound 4, concentration lethal to 50% of the cells: > 100000 nM
Compound 4: a limit, no number; the forecaster's own chance of this, stated with the estimate: 80%; at least 2.0-fold (0.30 log units) between middle value and limit.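

Compound 4 returns only a limit of the test, > 100000 nM, and with compound 2 also at a limit, no step can be read from compound 2 to compound 4. The compounds shown leave open whether phenyl in place of (3,4-dichlorophenyl)amino on a carbonyl carbon changes toxicity in this assay at all.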